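The compounds below may be only part of what the source reports. "The series", "measured", "known", "first", "only" and "open" are said of these compounds alone.

Compound 1 `CC(C)CCn1ccc(N2CCC(c3ccccc3)CC2)c(C#N)c1=O` is the reference point of the pair measured so far. In a functional assay on CHO cells for positive allosteric modulation of metabotropic glutamate receptor 2 (Homo sapiens), with a stated time of 30 min (a lower number here means a smaller maximal response, a higher number a larger maximal response), compound 1 gives 268%, the highest of the two numbers. Compound 2 `CC(C)CCn1ccc(N2CCCCC2)c(C#N)c1=O`, which carries hydrogen in place of phenyl on a saturated ring carbon, gives 185%; the step of a number 83 percentage points lower from compound 1 to compound 2 (beyond the scatter) lies beyond the scatter and is large.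

Compound 3 `N#Cc1c(N2CCC(c3ccccc3)CC2)ccn(CC2CC2)c1=O` is not yet measured. It differs from compound 1 at a different site: cyclopropyl in place of isobutyl on a saturated chain carbon bound to an aromatic nitrogen, or, cut one bond further out, isopentyl to cyclopropylmethyl. Among the compounds with values here, the one measured step concerns the phenyl on the saturated ring carbon, not the chain on the aromatic nitrogen, so no measured step bears on this change; the phenyl that compound 1 owes its maximal response to is kept in compound 3. Without evidence for the chain, a modest loss against compound 1 is allowed for, with wide uncertainty: compound 3 is expected to show 220% in this assay, in the range 140% to 290%, i.e. an estimated step of a number 48 percentage points lower from compound 1 to compound 3 (beyond the scatter).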

Compound 3, largest response reached (Emax), in percent of the reference or control that the assay uses: 309%
Compound 3: the middle estimate sits 89 percentage points below what was measured, and the stated range ends below it.
By their numbers in this assay, from the lowest: compound 2; then compound 1; then compound 3.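

In this assay the chain on the aromatic nitrogen proves to be a second site that moves the maximal response: cyclopropyl in place of isobutyl gives a number 41 percentage points higher from compound 1 to compound 3 (beyond the scatter), with the phenyl on the saturated ring carbon unchanged. Until now only the phenyl site had a measured step, and this one shows that the isopentyl chain of compound 1 is not needed for a high response, since cyclopropylmethyl exceeds it. No measurement at hand accounts for this gain.

The compounds shown leave open whether the gain from cyclopropylmethyl also appears without the phenyl, as no compound pairs that chain with hydrogen on the saturated ring carbon. They also leave open how other groups on the aromatic nitrogen, such as cyclobutylmethyl, benzyl or a longer chain, compare with cyclopropylmethyl.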